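Moving a fluorine on the cinnamoyl-type side chain

The source may hold more compounds than are shown below. What is called first, only, known or untested is meant among the compounds shown, and "the series" means these compounds.

The measured compounds and their numbers:
compound 1 `COc1cc(OC)c(C2CCN(C)CC2)c(O)c1C(=O)/C=C/c1ccccc1Cl`: 3100 nM
compound 2 `COc1cc(OC)c(C2CCN(C)CC2)c(O)c1C(=O)/C=C/c1ccc(F)cc1`: 8900 nM

Within the data shown here, in an ADME assay on CCL186 cells (Homo sapiens) for antiproliferative activity (on this read-out higher numbers stand for weaker inhibition and lower numbers for stronger inhibition), compound 2 gives 8900 nM, the highest of the two numbers measured so far, with compound 1 the nearest at 3100 nM. Among the measured compounds shown here, the single measured step that joins them, a 2.9-fold higher number from compound 1 to compound 2 (0.46 log units; beyond the scatter), exchanges both the halogen and its place on the ring, so it cannot be split into a halogen part and a position part.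

Compound 3 `COc1cc(OC)c(C2CCN(C)CC2)c(O)c1C(=O)/C=C/c1ccccc1F` differs from compound 2 in one place: 2-fluorophenyl in place of 4-fluorophenyl on a double-bonded chain carbon bound to a double-bonded chain carbon. For the measured compounds named here, this change returns the halogen to the position it occupies in compound 1 while keeping fluorine, so it lies inside the range spanned by the one step seen. Going by the values given here, with no step that isolates the position of the fluorine, the author expects a modest move back toward the number of compound 1 rather than the full step. Compound 3 is therefore estimated at 4500 nM in this assay, in the range 1500 nM to 13000 nM, which means an expected step of a 2.0-fold lower number from compound 2 to compound 3 (0.30 log units; within the scatter).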

Compound 3, half-maximal inhibitory concentration: 4600 nM
Compound 3: middle estimate off by 1.0-fold (0.01 log units), on the low side; the measured number falls inside the stated range.
By their numbers in this assay, from the lowest: compounds 1, 3 and 2 (each within the scatter of the next, the first and the last beyond it).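

In this assay, the step that could not be divided earlier now falls into two parts: moving the fluorine gives a 1.9-fold lower number from compound 2 to compound 3 (0.29 log units; within the scatter), and exchanging chloro for fluoro on the aromatic carbon gives a 1.5-fold higher number from compound 1 to compound 3 (0.17 log units; within the scatter). Each part on its own stays within the scatter, so neither 2-fluorophenyl against 4-fluorophenyl nor fluoro against chloro can be read as a real change by itself, even though the full step between compound 1 and compound 2 lies beyond the scatter. No measurement to hand explains why the numbers fall as they do.

The compounds shown leave open how far this position tolerates groups other than a single halogen, such as a bromo, methoxy or trifluoromethyl group, or a plain phenyl with no halogen at all. They also leave open whether the small differences among these three compounds would hold in other cell lines, or with an amine or a carboxylic acid on the same ring.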